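Permeability notes: trimming the aryl substituent in the sulfone series

A few compounds are considered here, and "the series" means these few. Any claim that something is new, unique, unknown or untested is made for them only; others in the source may bear on it.

Among the measured compounds shown here, compound 1 `CCCCc1nc(=O)c(S(=O)(=O)c2ccc(-n3ccccc3=O)cc2)c(O)n1-c1c(OC)cccc1OC` is the only member of this series with a number in an ADME assay for permeability, using PAMPA, at pH 5.5; a lower number here means that the compound crosses the layer more slowly, a higher number that the compound crosses the layer faster: in this assay compound 1 gives 12 nm/s, the sole reading available. Compound 2 `CCCCc1[nH]c(=O)c(S(=O)(=O)c2ccc(-c3ccc(F)cc3)cc2)c(O)c1-c1c(OC)cccc1OC` shares the butyl chain, the sulfone and the dimethoxyphenyl group, but in this assay compound 2 gives "not determined" (no result reported), so it offers no anchor. For the measured compounds named here, no step between two measured compounds exists, and nothing is known about how the compounds bind.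

Compound 3 `CCCCc1nc(=O)c(S(=O)(=O)c2ccc(C)cc2)c(O)n1-c1c(OC)cccc1OC` differs from compound 1 by one carbon atom in place of a group of 7 heavy atoms (5 carbon, 1 nitrogen, 1 oxygen; one six-membered aromatic ring with 1 hetero atom), on an aromatic carbon, in words one carbon atom in place of a group of 7 heavy atoms (5 carbon, 1 nitrogen, 1 oxygen; one six-membered aromatic ring with 1 hetero atom), on an aromatic carbon. With only the value of compound 1 as reference, the step is expected to be upward and beyond the scatter, with a 3.3-fold higher number from compound 1 to compound 3 (0.52 log units; beyond the scatter) as the estimated change. Compound 3 is expected to give 40 nm/s in this assay, within a range from 12 nm/s to 150 nm/s.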

Compound 3, apparent permeability: 243 nm/s
For compound 3 the middle estimate is 6.1-fold (0.78 log units) below the measured one; the whole stated range lies below it.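

Swapping the group of 7 heavy atoms for methyl, on an aromatic carbon para to a large group, gives a 20-fold higher number from compound 1 to compound 3 (1.31 log units; beyond the scatter) in this assay, so this position strongly influences the read-out. The change removes a six-membered aromatic ring with 1 hetero atom, 1 double bond outside aromatic rings and 2 hydrogen-bond acceptors together, and this single comparison cannot separate their contributions. The available data offer no measured explanation for the size of the step.

As far as these compounds go, it remains open whether the higher number depends on the loss of the ring or on methyl itself; a plain phenyl ring, an amine or a carboxylic acid at this place would help to separate the two. From the compounds shown here alone, the contribution of the butyl chain also remains open, as the compounds with readings share it, and a propyl chain would test it.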